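Swapping Chloro for Fluoro in Two Cytotoxic Cores

A few compounds are considered here, and "the series" means these few. Any claim that something is new, unique, unknown or untested is made for them only; others in the source may bear on it.

Compound 1 `O=C1/C(=C/c2ccccc2F)CN(Cc2cn(Cc3ccccc3F)nn2)C/C1=C\c1ccccc1F` and compound 2 `O=C1/C(=C/c2ccccc2F)CN(Cc2cn(Cc3ccccc3Cl)nn2)C/C1=C\c1ccccc1F` share one core and differ only in the halogen on a benzyl ring. In a functional assay on PC-3 cells (Homo sapiens) for cytotoxicity, read by MTT assay, with a stated time of 24 h (on this read-out higher numbers stand for weaker inhibition and lower numbers for stronger inhibition), compound 2 gives 7100 nM and compound 1 gives 19700 nM. The change fluoro in place of chloro on an aromatic carbon thus produced a 2.8-fold higher number from compound 2 to compound 1 (0.44 log units; beyond the scatter). Compound 3 `COc1ccc(/C=C2\CN(Cc3cn(Cc4ccccc4Cl)nn3)C/C(=C\c3ccc(OC)cc3)C2=O)cc1` is built on a different core; the difference between the two cores is not broken down here. In this assay compound 3 gives 36300 nM. Compound 4 `COc1ccc(/C=C2\CN(Cc3cn(Cc4ccccc4F)nn3)C/C(=C\c3ccc(OC)cc3)C2=O)cc1` is related to compound 3 by the same change, (fluoro in place of chloro on an aromatic carbon), at a place described in the same words. Among the compounds with values here, only one measured example of this change exists, in a different core, so any expectation for compound 4 is uncertain. Compound 4 is expected to give 80000 nM in this assay, with a likely range from 30000 nM to 200000 nM. This rests on a 2.8-fold higher number from compound 2 to compound 1 (0.44 log units; beyond the scatter), a single precedent. For compound 4 the expected step is therefore a 2.2-fold higher number from compound 3 to compound 4 (0.34 log units; beyond the scatter), a weakening of a similar size, widened by the change of core.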

Compound 4, half-maximal inhibitory concentration: 39900 nM
For compound 4 the middle estimate is 2.0-fold (0.30 log units) above the measured one; measured number inside the range.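

In this assay, replacing 2-chlorobenzyl with 2-fluorobenzyl on the methoxy-bearing core gives a 1.1-fold higher number from compound 3 to compound 4 (0.04 log units; within the scatter), so compound 3 and compound 4 cannot be told apart on this read-out. Although only the first of the two steps lies beyond the usual variation between repeats, the steps themselves cannot be separated: the same change on two cores in this assay, a 2.8-fold higher number (0.44 log units; beyond the scatter) from compound 2 to compound 1 and a 1.1-fold higher number (0.04 log units; within the scatter) from compound 3 to compound 4, 2.5-fold (0.40 log units) apart, within the scatter of two such steps. This shows that the result on the second core is compatible with the first, but it does not show that the change carries over with a fixed size, nor that the core alters its size, since two pairs are too few to decide either way.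

The compounds shown leave open whether a bromo, methyl or methoxy group on the benzyl ring in the same place would give a clearly different number from chloro or fluoro. They also leave open whether a benzyl ring with no such group, or one bearing an amine, would do so on either core.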